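A shorter hydroxycarbamoyl arm on the shared core

The source may hold more compounds than are shown below. What is called first, only, known or untested is meant among the compounds shown, and "the series" means these compounds.

Compound 1 `O=C(NO)c1ccc(-c2cn([C@@H]3C[C@H](C(=O)O)N(Cc4ccccc4)C3)nn2)cc1` was tested in an assay on Sf9 cells for inhibition of histone deacetylase 11 (Homo sapiens), read by fluorescence, tested at 0.5 uM; a higher number here means more inhibition at the concentration tested (going by the name of the read-out), a lower number less inhibition. In this assay compound 1 gives only a limit, < 10%. Compound 2 `O=C(NO)c1ccc(-c2cn([C@@H]3C[C@H](C(=O)O)N(CCCc4ccccc4)C3)nn2)cc1` carries phenethyl in place of phenyl on a saturated chain carbon bound to an amine nitrogen in a ring. In this assay compound 2 likewise gives only a limit, < 10%. The step that the two limits leave unreadable from compound 1 to compound 2 therefore cannot be read, and the limit of < 10% in this assay, at which 2 of the 2 values shown sit, is all the evidence there is. Compound 3 `O=C(/C=C/c1cn([C@@H]2C[C@H](C(=O)O)N(Cc3ccccc3)C2)nn1)NO` differs from compound 1 by 2-(hydroxycarbamoyl)ethenyl in place of 4-(hydroxycarbamoyl)phenyl on an aromatic carbon. Among the compounds with values here, no measured step bears on this change. Compound 3 is expected to remain near the limit, estimated at 5% (range 0% to 15%), which means an expected step that the limit leaves unreadable from compound 1 to compound 3 not beyond the scatter.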

Compound 3, a percentage reported as inhibition, at one concentration (the size of the read-out at that concentration, not a potency): < 10%
Compound 3 ended at the assay's limit; the forecaster's own chance of this, stated with the estimate: 75%; the middle value is on the limit's open side.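

Like compound 1, compound 3 gives only a limit in this assay, so the step between these two compounds cannot be read: the limit of < 10% in this assay, at which 3 of the 3 values shown sit.

Going by these compounds, whether 2-(hydroxycarbamoyl)ethenyl and 4-(hydroxycarbamoyl)phenyl differ in their effect on the shared core stays open.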